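Swapping an aminophenyl for a dimethoxyphenyl on the ketone

The source may hold more compounds than are shown below. What is called first, only, known or untested is meant among the compounds shown, and "the series" means these compounds.

Of the compounds shown here, three sharing one core have been measured so far. In a functional assay on KM12 cells (Homo sapiens) for cytotoxicity, read by sulforhodamine B assay, with a stated time of 48 h, tested at 10 uM (on this read-out lower numbers stand for a stronger effect and higher numbers for a weaker effect at the one concentration tested), compound 1 `COc1cc(-c2cc(/C=C/C(=O)c3ccc(N)cc3)[nH]n2)cc(OC)c1OC` gives -67%. Compound 3 `COc1ccc(-c2cc(/C=C/C(=O)c3ccc(N)cc3)[nH]n2)cc1` gives -67% in this assay, which at the digits shown is level with compound 1, and the two together are the highest of the three numbers. Compound 2 `COc1ccc(-c2cc(/C=C/C(=O)c3cc(OC)c(OC)c(OC)c3)[nH]n2)cc1OC` gives -81% in this assay, a number that stands below that of compound 1 by more than the usual scatter, making it the furthest of the three from compound 1.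

Compound 4 `COc1ccc(C(=O)/C=C/c2cc(-c3cc(OC)c(OC)c(OC)c3)n[nH]2)cc1OC` has not yet been measured. It differs from compound 1 in one place: 3,4-dimethoxyphenyl in place of 4-aminophenyl on a carbonyl carbon. For the measured compounds named here, no single-change step between measured compounds is available to calibrate this swap. Still, compound 2, which also carries methoxy groups on the aryl attached to the carbonyl carbon, gives -81%, so a step toward lower numbers is expected for compound 4, of the size a number 9 percentage points lower from compound 1 to compound 4 (within the scatter). Compound 4 is therefore estimated to give -76% in this assay, with a range from -92% to -58%.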

Compound 4, a percentage reported as activity, at one concentration (the size of the read-out at that concentration, not a potency): -87%
Compound 4: the middle estimate sits 11 percentage points above what was measured, and the stated range covers the measured number.
By their numbers in this assay, from the lowest: compounds 4 and 2 (each within the scatter of the next); then compounds 1 and 3 (each within the scatter of the next).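

The change on the carbonyl carbon can now be read on its own: in this assay, 3,4-dimethoxyphenyl in place of 4-aminophenyl gives a number 20 percentage points lower from compound 1 to compound 4 (beyond the scatter), so the group at this position does shift the read-out on the shared core. The earlier compounds shown here offered no single-change step at this position. Nothing measured here accounts for the step, which rests on this one pair.

From the compounds shown here alone, whether the methoxy groups or the loss of the amine matters more stays open, and an unsubstituted phenyl or a pyridyl on the same carbonyl carbon would help to separate the two. Also open, going by these compounds, is whether the step would keep its size on the core of compound 3, which carries 4-aminophenyl at this position too.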